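Chain variation on the ring nitrogen of a benzimidazole-piperazine series

The source may report more compounds than this note shows. Statements on the series, on what has been measured and on what is new or still open speak of the compounds shown alone.

Three analogues sharing one core have been run in a functional assay on ileum for inhibition of histamine H1 receptor (Cavia porcellus); a higher number here means a weaker inhibitor, a lower number a stronger inhibitor. Compound 1 `CCOCCn1c(N2CCN(C)CC2)nc2ccccc21` gives 10 nM. Compound 2 `CCCCCCCCCCn1c(N2CCN(C)CC2)nc2ccccc21` gives 4200 nM, and compound 3 `CCCSCn1c(N2CCN(C)CC2)nc2ccccc21` gives 68 nM. Compound 3 thus stands second highest of the three; its nearest neighbour is compound 1, the step of a 6.8-fold higher number from compound 1 to compound 3 (0.83 log units; beyond the scatter) lying beyond the scatter, while compound 2 sits far higher.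

The next compound, compound 4 `CCCCOCCn1c(N2CCN(C)CC2)nc2ccccc21`, differs from compound 3 by butoxymethyl in place of propylsulfanyl on a saturated chain carbon bound to an aromatic nitrogen. Two measured steps speak to this. The change a 6.8-fold higher number from compound 1 to compound 3 (0.83 log units; beyond the scatter), read in reverse, is the return from a propylsulfanyl to an ether-type chain, which points toward a lower number. Against it, a 420-fold higher number from compound 1 to compound 2 (2.62 log units; beyond the scatter) shows that lengthening the chain on the same ring nitrogen pushes the number sharply up, and compound 4 carries a longer chain than compound 1. The two pulls partly cancel, so a modest drop from compound 3, perhaps only at the edge of the scatter, is expected in this assay, as a 1.7-fold lower number from compound 3 to compound 4 (0.23 log units; within the scatter).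

Compound 4 is therefore estimated at 40 nM in this assay, with a range of 10 nM to 160 nM.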

Compound 4, half-maximal inhibitory concentration: 38 nM
Estimate against measurement, compound 4: 1.1-fold (0.02 log units) above; low and high end bracket the measured number.
By their numbers in this assay, from the lowest: compound 1; then compounds 4 and 3 (each within the scatter of the next); then compound 2.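

In this assay, the exchange of propylsulfanyl for butoxymethyl on a saturated chain carbon bound to an aromatic nitrogen gives a 1.8-fold lower number from compound 3 to compound 4 (0.25 log units; within the scatter), so the read-out does not separate these two chains. Within the chains that keep the oxygen, ethyl in place of hydrogen on a saturated chain carbon, two bonds along the chain from an oxygen on a saturated carbon, gives a 3.8-fold higher number from compound 1 to compound 4 (0.58 log units; beyond the scatter), a modest step for this extension of the chain. Butoxy in place of octyl on a saturated chain carbon, two bonds along the chain from an aromatic nitrogen, gives a 110-fold lower number from compound 2 to compound 4 (2.04 log units; beyond the scatter), so the very high number of compound 2 does not carry over to the 2-butoxyethyl chain of compound 4. Nothing at hand gives a reason for any of these steps.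

The step from compound 3 to compound 4 changes both the chain length and the sulfur-for-oxygen atom at once, so a 2-(butylsulfanyl)ethyl chain would be needed to read the two apart. Going by these compounds, how a chain ending in an amine or a carboxylic acid would behave at this position remains open.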